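The source may hold more compounds than are shown below. What is called first, only, known or untested is meant among the compounds shown, and "the series" means these compounds.

Compound 1, `O=C(CSc1nnc(-c2ccncc2)n1-c1ccccc1)N/N=C/c1ccc([N+](=O)[O-])cc1`: 15900 nM
Compound 2, `O=C(CSc1nnc(-c2ccncc2)n1-c1ccccc1)N/N=C/c1ccc(O)cc1`: in this assay it reaches only a limit, > 50000 nM
Compound 3, `O=C(CSc1nnc(-c2ccncc2)n1-c1ccccc1)N/N=C/c1ccccc1F`: 15200 nM

In a functional assay on HepG2 cells (Homo sapiens) for inhibition, read by MTT assay, with a stated time of 48 h (a lower number here means a stronger inhibitor, a higher number a weaker inhibitor), compound 3 holds the lowest of the two numbers given, with the limit of compound 2 standing apart. The nearest number belongs to a pair whose step, a 1.0-fold lower number from compound 1 to compound 3 (0.02 log units; within the scatter), lies within the scatter, so neither can be ranked above the other.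

Compound 4, `O=C(CSc1nnc(-c2ccncc2)n1-c1ccccc1)N/N=C/c1cc(Br)ccc1O`, differs from compound 3 by 5-bromo-2-hydroxyphenyl in place of 2-fluorophenyl on a carbon with a double bond to nitrogen. Going by the values given here, two measured steps bear on this change. The first, an at least 3.1-fold higher number from compound 1 to compound 2 (0.49 log units; beyond the scatter), shows a hydroxy entering the aromatic ring and the number rising past the limit (the limit of > 50000 nM in this assay, at which 1 of the 3 values shown sits). The second, an at least 3.2-fold lower number from compound 2 to compound 3 (0.51 log units; beyond the scatter), shows the hydroxyphenyl leaving and the number falling. Both point the same way: a ring carrying a hydroxy has given a higher number. Compound 4 returns a hydroxy to the ring and adds a bromine, for which no comparison exists among the measured compounds. The step from compound 3 to compound 4 is therefore expected to be a 2.3-fold higher number from compound 3 to compound 4 (0.36 log units; beyond the scatter), with a real chance that only a limit is reported. Compound 4 is estimated at 35000 nM, with a range from 12000 nM to 50000 nM.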

Compound 4, half-maximal inhibitory concentration: 4390 nM
Compound 4: middle estimate off by 8.0-fold (0.90 log units), on the high side, and the stated range ends above it.
By their numbers in this assay, from the lowest: compound 4; then compounds 3 and 1 (each within the scatter of the next). At a limit, above all of these: compound 2.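

In this assay, a hydroxy on the ring at this position no longer goes with a higher number: with 5-bromo-2-hydroxyphenyl on the carbon with a double bond to nitrogen, the result is a 3.5-fold lower number from compound 3 to compound 4 (0.54 log units; beyond the scatter) and a 3.6-fold lower number from compound 1 to compound 4 (0.56 log units; beyond the scatter). Against 4-hydroxyphenyl the change is larger, an at least 11-fold lower number from compound 2 to compound 4 (1.05 log units; beyond the scatter), but this step starts from a limit held by compound 2, not from a number: the limit of > 50000 nM in this assay, at which 1 of the 4 values shown sits.

The compounds shown do not separate the part played by the bromine in compound 4 from that of the hydroxy. As far as these compounds go, how a chlorine, a methoxy or an amine on this ring would compare remains open.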